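A few compounds are considered here, and "the series" means these few. Any claim that something is new, unique, unknown or untested is made for them only; others in the source may bear on it.

Within the data shown here, the three compounds measured so far share one core and differ at its edges. Compound 1 `CCN(CC)CCCN(C(=O)c1ccc(-c2ccccc2)[nH]1)C(C(=O)NC1CCCCC1)c1ccc(F)cc1` gives 1290 nM in an assay on isolated protein for binding affinity to growth hormone secretagogue receptor type 1 (Homo sapiens); a higher number here means a weaker inhibitor, a lower number a stronger inhibitor. Compound 2 `CCN(CC)CCN(C(=O)c1ccc(-c2ccccc2)[nH]1)C(C(=O)NC1CCCCC1)c1ccc(F)cc1`, which carries diethylamino in place of (diethylamino)methyl on a saturated chain carbon, two bonds along the chain from an amide-type nitrogen, gives 1370 nM in this assay; the step of a 1.1-fold higher number from compound 1 to compound 2 (0.03 log units; within the scatter) shows that shortening that chain makes no difference that can be told from the scatter. Compound 3 `CCN(CC)CCCN(C(=O)c1ccc(-c2ccccc2)[nH]1)C(C)C(=O)NC(C)(C)C` gives 1180 nM in this assay, the lowest of the three numbers, though it sits within the scatter of both compound 1 and compound 2, so no order among them can be read off.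

Compound 4 `CCN(CC)CCCN(C(=O)c1ccc(-c2ccccc2)[nH]1)C(C)C(=O)NC1CCCCC1` has not yet been measured. It differs from compound 3 in one place: cyclohexyl in place of tert-butyl on an amide-type nitrogen. Among the measured compounds shown here, none of the measured steps touches this amide-type nitrogen, so there is no direct precedent for the exchange. Compounds 1 and 3 differ at that position, but at a second place as well, and their two values are within the scatter of each other. On this basis compound 4 is expected to stay close to compound 3, with a step of a 1.1-fold lower number from compound 3 to compound 4 (0.03 log units; within the scatter) that is not expected to rise beyond the scatter. Compound 4 is therefore estimated at 1100 nM, with a range from 450 nM to 2800 nM.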

Compound 4, inhibition constant: 1920 nM
For compound 4 the middle estimate is 1.7-fold (0.24 log units) below the measured one; the range from low to high includes it.
By their numbers in this assay, from the lowest: compounds 3, 1, 2 and 4 (each within the scatter of the next).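

In this assay, the exchange of tert-butyl for cyclohexyl on the amide-type nitrogen can now be read on its own, as a 1.6-fold higher number from compound 3 to compound 4 (0.21 log units; within the scatter), so at this position the larger group with its six-membered non-aromatic ring gives no difference that can be told from the scatter. The second new comparison isolates the other edge, the saturated chain carbon bound to an amide-type nitrogen and a carbonyl carbon, where methyl in place of 4-fluorophenyl comes to a 1.5-fold higher number from compound 1 to compound 4 (0.17 log units; within the scatter), so removing the 4-fluorophenyl group there also leaves no readable difference. No other measurement bears on these results.

The groups on the amide-type nitrogen shown here are all built of carbon alone, so it remains open whether an amine or a carboxylic acid on that group would give a step beyond the scatter. On these data alone, it also remains open whether dimethylamino in place of diethylamino at the end of the chain, or a longer chain carrying it, would separate from these values.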